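Swapping a benzoyl for a propylsulfanyl on a shared core

The compounds below may be only part of what the source reports. "The series", "measured", "known", "first", "only" and "open" are said of these compounds alone.

Measured compounds:
Compound 1 `COC(=O)Nc1nc2cc(Oc3cccc(N4CCN(C)CC4)c3)ccc2[nH]1` gives 73.1%
Compound 2 `COC(=O)Nc1nc2cc(C(=O)c3ccc(N(C)C4COC4)cc3)ccc2[nH]1` gives 44.5%
Compound 3 `O=C(Nc1nc2cc(C(=O)c3ccccc3)ccc2[nH]1)OC1COC1` gives 90.9%

These three compounds were tested in a functional assay on PC-3 cells (Homo sapiens) for cytotoxicity, read by MTT assay, with a stated time of 72 h, tested at 1 uM; a lower number here means a stronger effect, a higher number a weaker effect of the compound at the concentration tested. Compound 3 stands highest of the three numbers, which means it had the weakest effect at the concentration tested. Its nearest neighbour is compound 1, whose number is lower by more than the usual scatter, and compound 2 lies furthest from it, also by more than the scatter.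

The next compound, compound 4 `CCCSc1ccc2[nH]c(NC(=O)OC3COC3)nc2c1`, has not yet been measured. It differs from compound 3 in one place: propylsulfanyl in place of benzoyl on an aromatic carbon.

Within the data shown here, no pair of measured compounds differs in only one place, so there is no measured step to lean on. The expectation for compound 4 is therefore uncertain, and a step from compound 3 to compound 4 of a number 25.9 percentage points lower from compound 3 to compound 4 (beyond the scatter) in this assay is only an estimate; the direction expected is downward, toward a stronger effect. Compound 4 is estimated to give 65%, within a range from 35% to 95%.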

Compound 4, a percentage reported as activity, at one concentration (the size of the read-out at that concentration, not a potency): 95.2%
The estimate for compound 4 lay 30.2 percentage points below the measured number, and the stated range ends below it.
By their numbers in this assay, from the lowest: compound 2; then compound 1; then compounds 3 and 4 (each within the scatter of the next).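

Among these compounds, replacing benzoyl with propylsulfanyl on this aromatic carbon gives, in this assay, a number 4.3 percentage points higher from compound 3 to compound 4 (within the scatter) as the first step that can be read at this position. The six-membered aromatic ring and the double bond of benzoyl can therefore leave this place, with an open chain carrying sulfur entering instead, without a difference beyond the scatter at the single concentration tested. Nothing available explains this outcome.

As far as these compounds go, whether an amine, a carboxylic acid or a chain longer than propylsulfanyl on this carbon would move the number remains open. This step also rests on a single pair, so it cannot show whether the same swap would read alike on a compound carrying a different group elsewhere on the shared core, or at another concentration.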